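The compounds below may be only part of what the source reports. "The series", "measured", "known", "first", "only" and "open" are said of these compounds alone.

Measured compounds in an assay on CHO cells for displacement of a labelled ligand from Substance-P receptor (Homo sapiens), in the presence of a further agent that is not named here; on this read-out lower numbers stand for stronger inhibition and higher numbers for weaker inhibition:
- compound 1, `C[C@@H](O[C@H]1CN2C(=O)C=C(c3ccc(CO)cc3)CC2[C@@H]1c1ccc(F)cc1)c1cc(C(F)(F)F)cc(C(F)(F)F)c1`, gives 23 nM
- compound 2, `C[C@@H](O[C@H]1CN2C(=O)C=C(c3ccncc3)CC2[C@@H]1c1ccc(F)cc1)c1cc(C(F)(F)F)cc(C(F)(F)F)c1`, gives 8.1 nM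
- compound 3, `C[C@@H](O[C@H]1CN2C(=O)C=C(c3cc[n+]([O-])cc3)CC2[C@@H]1c1ccc(F)cc1)c1cc(C(F)(F)F)cc(C(F)(F)F)c1`, gives 2.1 nM

Compound 2 stands second highest of the three numbers: compound 1 is nearest, at a 2.8-fold lower number from compound 1 to compound 2 (0.45 log units; beyond the scatter), and compound 3 furthest, at a 3.9-fold lower number from compound 2 to compound 3 (0.59 log units; beyond the scatter). Compound 4, `C[C@@H](O[C@H]1CN2C(=O)C=C(C3CCOCC3)CC2[C@@H]1c1ccc(F)cc1)c1cc(C(F)(F)F)cc(C(F)(F)F)c1`, differs from compound 2 by oxan-4-yl in place of pyridin-4-yl on a double-bonded ring carbon. Neither measured step bears directly on this change: both keep an aromatic ring at that position, and no saturated ring has been measured. The two steps show only that the pyridin-4-yl and its oxide gave lower numbers than 4-(hydroxymethyl)phenyl. With no direct guide, a modest rise in number is expected for compound 4, a 2.5-fold higher number from compound 2 to compound 4 (0.39 log units; beyond the scatter), giving an estimate of 20 nM, within 6 nM to 70 nM.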

Compound 4, half-maximal inhibitory concentration: 3.2 nM
Compound 4: middle estimate off by 6.3-fold (0.80 log units), on the high side, outside the stated range (below it).
By their numbers in this assay, from the lowest: compounds 3 and 4 (each within the scatter of the next); then compound 2; then compound 1.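

In this assay, an aromatic ring is not required on this double-bonded ring carbon: the non-aromatic oxan-4-yl gives a 2.5-fold lower number from compound 2 to compound 4 (0.40 log units; beyond the scatter) and a 7.2-fold lower number from compound 1 to compound 4 (0.86 log units; beyond the scatter). Set against the oxide of pyridin-4-yl, oxan-4-yl gives a 1.5-fold higher number from compound 3 to compound 4 (0.18 log units; within the scatter), so the two cannot be told apart in this assay. No supporting evidence accounts for these steps. On these data alone, what remains open is how cyclohexyl, or piperidin-4-yl with its ring amine, would compare at this position, and so whether the ring oxygen of oxan-4-yl matters.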